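This account rests on a few compounds, and the source may have more. Where it says the series, first, only, none or still open, it means among the compounds named here.

Measured so far in an assay on CHO cells for displacement of a labelled ligand from prostaglandin E2 receptor EP3 subtype (Homo sapiens), read by radioligand binding; a higher number here means a weaker inhibitor, a lower number a stronger inhibitor:
compound 1 `CC(C)C(c1ccc(-c2ccc3cccc(F)c3c2)[nH]c1=O)N1CCCCC1=O`, 6.4 nM
compound 2 `CCn1ncc2c(C)cc(-c3ccc([C@@]4(C)CCNC4=O)c(=O)[nH]3)cc21`, 5 nM

Compound 1 holds the higher of the two numbers in this assay, yet its gap to compound 2 lies within the scatter, so the two cannot be ordered. Compound 3 `CC(C)C(c1ncc[nH]1)c1ccc(-c2ccc3cccc(F)c3c2)[nH]c1=O` keeps the core of compound 1 and differs in one place: 1H-imidazol-2-yl in place of 2-oxopiperidin-1-yl on a saturated chain carbon bound to an aromatic carbon and a saturated chain carbon. Among the measured compounds shown here, no measured pair shows this change, so its effect is unknown. The step expected here, a 2.3-fold higher number from compound 1 to compound 3 (0.37 log units; beyond the scatter), is small and of uncertain direction, with a wide range. Compound 3 is estimated at 15 nM in this assay, between 4 nM and 60 nM.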

Compound 3, inhibition constant: 7.3 nM
Compound 3: the middle estimate sits 2.1-fold (0.31 log units) above what was measured; measured number inside the range.
By their numbers in this assay, from the lowest: compounds 2, 1 and 3 (each within the scatter of the next).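

In this assay the change from 2-oxopiperidin-1-yl to 1H-imidazol-2-yl gives a 1.1-fold higher number from compound 1 to compound 3 (0.06 log units; within the scatter) and so no readable change on this saturated chain carbon. With the core of compound 1 held fixed, a five-membered aromatic ring with a hydrogen-bond donor therefore reads the same here as a six-membered non-aromatic ring without one. Nothing measured bears on why the two groups read alike. Still open, on these data alone, is whether 1-methylimidazol-2-yl, which lacks that donor, would also read the same. As far as these compounds go, an amine or a carboxylic acid at this place also remains untested here.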